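A few compounds are considered here, and "the series" means these few. Any claim that something is new, unique, unknown or untested is made for them only; others in the source may bear on it.

Measured in an assay on cells for inhibition of interleukin-5 receptor subunit alpha (Mus musculus), read by WST assay, with a stated time of 48 h, in the presence of a further agent that is not named here; a higher number here means a weaker inhibitor, a lower number a stronger inhibitor:

- compound 1 `OCCCCNCc1nc2c(OCC3CCCCC3)cccc2[nH]1`: compound 1 gives 30000 nM
- compound 2 `OCCCCCNCc1nc2c(OCC3CCCCC3)cccc2[nH]1`: compound 2 gives > 30000 nM, which is a limit of the assay and not a number
- compound 3 `CCCC(CO)NCc1nc2c(OCC3CCCCC3)cccc2[nH]1`: compound 3 gives 7500 nM

Among the numbers shown, compound 1 has the highest one; its nearest neighbour is compound 3, with a 4.0-fold lower number from compound 1 to compound 3 (0.60 log units; beyond the scatter). Compound 2 sits at a limit, (the limit of > 30000 nM in this assay, at which 1 of the 3 values shown sits), so the step of a number no lower from compound 1 to compound 2 (the limit leaves the size open) cannot be sized.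

Compound 4 `c1ccc(NCc2nc3c(OCC4CCCCC4)cccc3[nH]2)cc1` differs from compound 1 in one place: phenyl in place of 4-hydroxybutyl on an amine nitrogen. The measured steps all concern one hydroxyalkyl chain in place of another on the same amine nitrogen, and none of them removes the hydroxy group or brings in an aromatic ring. The branched chain of compound 3 lowered the number by a 4.0-fold lower number from compound 1 to compound 3 (0.60 log units; beyond the scatter) and, against compound 2, by an at least 4.0-fold lower number from compound 2 to compound 3 (0.60 log units; beyond the scatter); the longer straight chain of compound 2 gave no lower number than compound 1. These steps say how the chains compare with each other, and nothing direct about a phenyl at this position.

Among the measured compounds shown here, with no bearing step, the expectation for compound 4 is a number near that of compound 1, with a wide range and a real chance that the assay reports only a limit. Compound 4 is estimated at 20000 nM, between 5000 nM and 60000 nM, which means an expected step of a 1.5-fold lower number from compound 1 to compound 4 (0.18 log units; within the scatter).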

Compound 4, half-maximal inhibitory concentration: > 30000 nM
Compound 4 ended at the assay's limit; the forecaster's own chance of this, stated with the estimate: 35%; at least 1.5-fold (0.17 log units) between middle value and limit.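

In this assay compound 4 gives > 30000 nM, which is a limit of the assay and not a number: the limit of > 30000 nM in this assay, at which 2 of the 4 values shown sit.

Phenyl on this amine nitrogen brings an aromatic ring and removes the hydroxy group, and set against the branched chain this change gives an at least 4.0-fold higher number from compound 3 to compound 4 (0.60 log units; beyond the scatter), so in this series phenyl does not match 1-(hydroxymethyl)butyl at this position. Set against 4-hydroxybutyl, phenyl gives a number no lower from compound 1 to compound 4 (the limit leaves the size open), so phenyl cannot be ranked against this chain. The step to compound 4 from compound 2 cannot be read, so phenyl cannot be ranked against 5-hydroxypentyl either, and this result adds a comparison of readable size only with the branched chain.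

On these data alone, it remains open whether the hydroxy group or the aromatic ring accounts for the result with compound 4: a plain butyl chain would test the loss of the hydroxy group without a ring, while a 4-hydroxyphenyl or a benzyl group on the same nitrogen would test the ring in other forms. Also open, as far as these compounds go, is how far the branched chain can be varied, for example with a 1-(hydroxymethyl)propyl or a 1-(hydroxymethyl)pentyl group on this amine nitrogen.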